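The source may hold more compounds than are shown below. What is called first, only, known or untested is meant among the compounds shown, and "the series" means these compounds.

Working notes on the series, read in an ADME assay on a cell-free system (plasma, Mus musculus) for metabolic stability, tested at 1 uM; on this read-out lower numbers stand for a shorter-lived compound and higher numbers for a longer-lived compound. Of the compounds shown here, three built on the shared core have been measured: compound 1 `C=CC(=O)NC1CCN(S(=O)(=O)c2ccc(C(=O)NCc3ccccc3)cc2)CC1`, compound 2 `C=CC(=O)NC1CCN(S(=O)(=O)c2ccc(C(=O)NCCCc3ccccc3)cc2)CC1` and compound 3 `C=CC(=O)NC1CCN(S(=O)(=O)c2ccc(C(=O)NCCC3CCCCC3)cc2)CC1`. Compound 1 gives > 6 h, which is a limit and not a number. Compound 2 gives > 6 h, again a limit. Compound 3 gives > 6 h, also a limit, so it stands without a number of its own.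

The next compound is compound 4 `C=CC(=O)NC1CCN(S(=O)(=O)c2ccc(C(=O)NCc3cccc4ccccc34)cc2)CC1`, with naphthalen-1-yl in place of cyclohexylmethyl on a saturated chain carbon bound to an amide-type nitrogen. Cut one bond further out, the same difference reads 2-cyclohexylethyl to (naphthalen-1-yl)methyl.

The measured steps that bear on this change are a step that the two limits leave unreadable from compound 1 to compound 3, a step that the two limits leave unreadable from compound 1 to compound 2 and a step that the two limits leave unreadable from compound 2 to compound 3. None of them has a readable size, so the series gives no measured size for a change at this place. No step beyond the scatter is expected in this assay for compound 4, since compound 1, compound 2 and compound 3 share (the limit of > 6 h in this assay, at which 3 of the 3 values shown sit). A further limit is the likeliest report. The estimated step is a step that the limit leaves unreadable from compound 3 to compound 4. Compound 4 is estimated at 8 h, with an expected range of 5 h to 15 h.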

Compound 4, half-life: > 6 h
Compound 4: only a limit was reported (the forecaster's own chance of this, stated with the estimate: 85%); the middle value does not contradict the limit.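

In this assay compound 4 gives > 6 h, a limit and not a number. Its steps from compound 1, compound 2 and compound 3 cannot be read, and the series sits at a single limit: the limit of > 6 h in this assay, at which 4 of the 4 values shown sit. The compounds shown leave open how long each one actually lasts and whether the groups at this place differ at all.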